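The compounds below may be only part of what the source reports. "The series", "measured", "known", "first", "only" and "open" are said of these compounds alone.

Compound 2 `Cc1ncc([N+](=O)[O-])n1CC(O)CN1CCN(c2ncccn2)CC1` and compound 1 `CCOC(=O)N1CCN(CC(O)Cn2c([N+](=O)[O-])cnc2C)CC1` differ only in the group on a ring nitrogen of the shared core. In a toxicity assay on HeLa cells (Homo sapiens) for cytotoxicity, read by MTT assay, with a stated time of 24 h (on this read-out higher numbers stand for weaker inhibition and lower numbers for stronger inhibition), compound 2 gives 3930000 nM and compound 1 gives 3670000 nM, two numbers within the scatter of each other. Compound 3 `Cc1ncc([N+](=O)[O-])n1CC(O)CN1CCN(c2cccc(Cl)c2)CC1` differs from compound 2 by 3-chlorophenyl in place of pyrimidin-2-yl on an amine nitrogen in a ring. Going by the values given here, the only measured step at that ring nitrogen, a 1.1-fold higher number from compound 1 to compound 2 (0.03 log units; within the scatter), showed no change beyond the scatter, so another swap of the group there is expected to leave the number much as it is. Compound 3 is therefore estimated at 3500000 nM, with a range from 1500000 nM to 8000000 nM. The expected step is a 1.1-fold lower number from compound 2 to compound 3 (0.05 log units; within the scatter).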

Compound 3, half-maximal inhibitory concentration: 1440000 nM
Compound 3: the middle estimate sits 2.4-fold (0.39 log units) above what was measured, outside the stated range (below it).
By their numbers in this assay, from the lowest: compound 3; then compounds 1 and 2 (each within the scatter of the next).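

The group on this ring nitrogen can move the number after all: in this assay, 3-chlorophenyl gives a 2.7-fold lower number from compound 2 to compound 3 (0.44 log units; beyond the scatter) and a 2.5-fold lower number from compound 1 to compound 3 (0.41 log units; beyond the scatter), both modest steps. Pyrimidin-2-yl and ethoxycarbonyl sit within the scatter of each other, so 3-chlorophenyl, with its carbon-only aromatic ring and chlorine, is the one group here that stands apart. Nothing available explains this shift.

Going by these compounds, it remains open whether the chlorine or the carbon-only ring accounts for the step. A plain phenyl, a methoxyphenyl or an acetyl group at this nitrogen could help separate these possibilities.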